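A few compounds are considered here, and "the series" means these few. Any claim that something is new, unique, unknown or untested is made for them only; others in the source may bear on it.

In a functional assay on HCT-15 cells (Homo sapiens) for inhibition (a higher number here means a weaker inhibitor, a lower number a stronger inhibitor), compound 1, `Oc1cccc(-c2cc(-c3cccc(F)c3)cc(-c3ccccc3O)n2)c1`, gives > 50000 nM, which is a limit of the assay rather than a measured number. Compound 2, `Oc1ccccc1-c1cc(-c2cccc(OC(F)(F)F)c2)cc(-c2ccccc2O)n1`, carries two 2-hydroxyphenyl groups on the shared core. In this assay compound 2 gives > 50000 nM, again a limit and not a number. Compound 2 therefore stands at the limit of > 50000 nM in this assay, at which 2 of the 2 values shown sit, and the two measured compounds cannot be placed in any order against each other.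

Compound 3, `Oc1cccc(-c2cc(-c3cccc(OC(F)(F)F)c3)cc(-c3ccccc3O)n2)c1`, differs from compound 2 by 3-hydroxyphenyl in place of 2-hydroxyphenyl on an aromatic carbon. Going by the values given here, no step between two measured compounds covers this change, and the only guide is that both compound 1 and compound 2 sit at the same limit in this assay. The same outcome is expected for compound 3, so the step expected in this assay is a step that the limit leaves unreadable from compound 2 to compound 3, nothing beyond the usual scatter. Compound 3 is expected to give about 80000 nM in this assay, with a range from 20000 nM to 300000 nM, and most probably the assay will again report only a limit for compound 3.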

Compound 3, half-maximal inhibitory concentration: 2740 nM
The estimate for compound 3 lay 29-fold (1.47 log units) above the measured number, and the stated range ends above it.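

In this assay, replacing 2-hydroxyphenyl with 3-hydroxyphenyl on the aromatic carbon next to the ring nitrogen gives an at least 18-fold lower number from compound 2 to compound 3 (1.26 log units; beyond the scatter), so where the hydroxyl sits on this ring matters even though the two compounds have the same atoms, joined differently. 3-Hydroxyphenyl at this place is not enough by itself, since compound 1 carries it too, and trifluoromethoxy in place of fluoro gives an at least 18-fold lower number from compound 1 to compound 3 (1.26 log units; beyond the scatter). Among these three compounds, only the one combining 3-hydroxyphenyl with trifluoromethoxy gives a number rather than a limit, and both steps are minimum sizes since each starts from a limit: the limit of > 50000 nM in this assay, at which 2 of the 3 values shown sit.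

From the compounds shown here alone, the true size of each step remains unknown, as does whether the two changes act independently or only work together. Going by these compounds, it is also open how this place would respond to 4-hydroxyphenyl, to plain phenyl, or to a ring carrying an amine or a carboxylic acid instead of the hydroxyl, and whether a group such as methoxy or trifluoromethyl could stand in for trifluoromethoxy.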